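The source may hold more compounds than are shown below. What is called first, only, known or untested is meant among the compounds shown, and "the series" means these compounds.

Measured so far:
compound 1 `c1ccc(CCc2ccc3c(NCCCNCc4ccco4)ccnc3c2)cc1`, permeability 23 10^-6 cm/s
compound 2 `COc1ccc(F)cc1CNCCCNc1ccnc2cc(Cc3ccc(F)cc3Cl)ccc12`, permeability 23 10^-6 cm/s
compound 3 `Fc1ccc(Cc2ccc3c(NCCCNCc4ccco4)ccnc3c2)c(Cl)c1`, permeability 23 10^-6 cm/s

In an ADME assay for permeability, using PAMPA, with a stated time of 30 min, at pH 7.4 (a lower number here means that the compound crosses the layer more slowly, a higher number that the compound crosses the layer faster), compound 2 gives 23 10^-6 cm/s, level with compound 1 and compound 3 at the digits shown. Compound 4 `COc1ccc(F)cc1CNCCCNc1ccnc2cc(-c3ccc(C(C)(C)C)cc3)ccc12` differs from compound 2 in one place: 4-(tert-butyl)phenyl in place of 2-chloro-4-fluorobenzyl on an aromatic carbon. For the measured compounds named here, two measured steps bear on this change. The step of no change at the digits printed from compound 1 to compound 3 (within the scatter) exchanged one group for another at the same part of the shared core, and the step of no change at the digits printed from compound 2 to compound 3 (within the scatter) exchanged the group on the saturated chain carbon bound to an amine nitrogen; neither moved the read-out beyond the scatter. The exchange in compound 4 is therefore expected to leave the read-out where compound 2 stands, with no step beyond the scatter. Compound 4 is estimated at 23 10^-6 cm/s, with a range from 12 10^-6 cm/s to 40 10^-6 cm/s. The expected step of no change at the digits printed from compound 2 to compound 4 (within the scatter) is within the scatter.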

Compound 4, apparent permeability: 237 10^-6 cm/s
The estimate for compound 4 lay 10-fold (1.01 log units) below the measured number, outside the stated range (above it).
By their numbers in this assay, from the lowest: compounds 1, 2 and 3 (each within the scatter of the next); then compound 4.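

In this assay, this aromatic carbon of the shared core proves able to move the read-out: 4-(tert-butyl)phenyl in place of 2-chloro-4-fluorobenzyl gives a 10-fold higher number from compound 2 to compound 4 (1.01 log units; beyond the scatter) while the earlier exchange at this place stayed level. The entering group attaches through a ring carbon, whereas the leaving group attaches through a saturated carbon. No measurement shown explains the step. The compounds shown leave open whether the rise follows the loss of that saturated carbon or the tert-butyl group; unsubstituted phenyl and 4-(tert-butyl)benzyl at this place would separate the two.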